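The compounds below may be only part of what the source reports. "The series", "measured", "known", "first", "only" and "open" are said of these compounds alone.

Of the compounds shown here, three that share a core have been tested in a functional assay on BJAB cells (Homo sapiens) for antiproliferative activity, with a stated time of 4 days; a higher number here means that more compound is needed for the effect, a lower number that less compound is needed. Compound 1 `Cc1nn(-c2nc(-c3ccc(Cl)c(Cl)c3)c(SC(C)C)s2)c(C(=O)O)c1-c1cccc(C(F)(F)F)c1` gives 22000 nM, the highest of the two numbers obtained. Compound 3 `Cc1c(-c2cc(Cl)cc(Cl)c2)c(C(=O)O)nn1-c1nc(-c2cc(Cl)cc(Cl)c2)c(SC(C)C)s1` gives 2000 nM. Compound 2 `Cc1oncc1-c1nc(-n2nc(C(=O)O)c(-c3cc(Cl)cc(Cl)c3)c2C)sc1SC(C)C` reaches only a limit of the assay, > 44000 nM, which is the limit of > 44000 nM in this assay, at which 1 of the 3 values shown sits. Among the compounds with values here, the single measured step between compounds that differ in one place is an at least 22-fold lower number from compound 2 to compound 3 (1.34 log units; beyond the scatter). Compound 4 `Cc1nn(-c2nc(-c3ccc(Cl)c(Cl)c3)c(SC(C)C)s2)c(C(=O)O)c1-c1ccccc1` differs from compound 1 in another way: hydrogen in place of trifluoromethyl on an aromatic carbon. The measured step concerns a different ring and does not bear on this change, so no step beyond the scatter is expected in this assay, in either direction. Compound 4 is therefore estimated at 30000 nM, with a range from 10000 nM to 90000 nM. That estimate means an expected 1.4-fold higher number from compound 1 to compound 4 (0.13 log units; within the scatter).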

Compound 4, half-maximal effective concentration: 3000 nM
Estimate against measurement, compound 4: 10-fold (1.00 log units) above; the whole stated range lies above it.
By their numbers in this assay, from the lowest: compounds 3 and 4 (each within the scatter of the next); then compound 1. At a limit, above all of these: compound 2.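

Going from 3-(trifluoromethyl)phenyl to phenyl gives a 7.3-fold lower number from compound 1 to compound 4 (0.87 log units; beyond the scatter) in this assay. Within the data shown here, the earlier step concerned a different ring, so this is the first sign that the group on this ring affects the number, and here the ring without trifluoromethyl needs less compound. Nothing shown explains why this change has that effect.

Going by these compounds, it remains open whether a methoxy group or an amine at this place would give a lower or a higher number than hydrogen. On these data alone, the effect of trifluoromethyl elsewhere on this ring also remains open.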